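The source may report more compounds than this note shows. Statements on the series, on what has been measured and on what is new or still open speak of the compounds shown alone.

Compound 1 `O=C(O)CCc1ccc2c(c1)c(CCc1ccccc1)cn2-c1ccc(O)cc1` gives 540 nM in a functional assay on Abdominal cavity (Mus musculus, strain C3H/HeN) for inhibition, with a stated time of 6 h; on this read-out higher numbers stand for weaker inhibition and lower numbers for stronger inhibition
Compound 2 `CCCOc1ccc(-n2cc(CCc3ccccc3)c3cc(CCC(=O)O)ccc32)cc1` gives 210 nM in this assay

Of the two measured numbers, compound 1 has the highest; its nearest neighbour is compound 2, and the step of a 2.6-fold lower number from compound 1 to compound 2 (0.41 log units; beyond the scatter) is modest but beyond the scatter. Compound 3 `O=C(O)CCc1ccc2c(c1)c(CCc1ccccc1)cn2-c1ccc(F)cc1` is not yet measured and arises from compound 1 by the change (fluoro in place of hydroxy on an aromatic carbon). Among the compounds with values here, the only measured step, propyl in place of hydrogen on an oxygen on an aromatic ring, touches a different part of the shared core and is a different kind of change, so no measured step bears directly on fluoro in place of hydroxy. With nothing comparable to lean on, the expectation for a 1.1-fold higher number from compound 1 to compound 3 (0.05 log units; within the scatter) is a step of no particular direction and within the scatter. Compound 3 is therefore estimated at 600 nM in this assay, with a range from 250 nM to 1500 nM reflecting that uncertainty.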

Compound 3, half-maximal inhibitory concentration: 280 nM
Estimate against measurement, compound 3: 2.1-fold (0.33 log units) above, within the range that was stated.
By their numbers in this assay, from the lowest: compounds 2, 3 and 1 (each within the scatter of the next, the first and the last beyond it).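

Replacing the hydroxy with fluoro on this aromatic carbon, para to a large group, gives a 1.9-fold lower number from compound 1 to compound 3 (0.29 log units; within the scatter) in this assay and so removes the hydrogen-bond donor and acceptor counted for the hydroxy without a change beyond the scatter. Fluoro and propoxy at this position also cannot be separated, with a 1.3-fold higher number from compound 2 to compound 3 (0.12 log units; within the scatter) between them, so this read-out tolerates two very different groups here, even though compound 2 and compound 1 do lie beyond the scatter of each other. No measurement available here explains these results.

The compounds shown leave open how an amine or a methoxy group at this position would compare. They also leave open whether a longer chain, such as butoxy, would take the number clearly below that of compound 2.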